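Replacing an Aromatic Group with a Butyl Chain

The source may report more compounds than this note shows. Statements on the series, on what has been measured and on what is new or still open speak of the compounds shown alone.

Compound 1 `COc1cc2c(cc1OC)C(=O)C(CC1CCN(C(=S)Nc3ccc([N+](=O)[O-])cc3)CC1)C2`: 100 mg/kg
Compound 2 `COc1cc2c(cc1OC)C(=O)C(CC1CCN(C(=S)Nc3ccc(Cl)cc3)CC1)C2`: 100 mg/kg

Going by the values given here, in a functional assay on the whole organism (strain Swiss albino) with Mus musculus as the target, with a stated time of 0.5 h (on this read-out higher numbers stand for an effect only at larger amounts of compound and lower numbers for an effect already at smaller amounts), compound 2 stands level with compound 1, the only other measured compound: the step of no change at the digits printed from compound 1 to compound 2 (within the scatter) shows no movement beyond the scatter. Compound 3 `CCCCNC(=S)N1CCC(CC2Cc3cc(OC)c(OC)cc3C2=O)CC1` differs from compound 2 by butyl in place of 4-chlorophenyl on an amide-type nitrogen. Among the compounds with values here, no measured step touches a change of this kind; the single known step concerns a different part of the molecule and was flat, so the numbers offer no direction. Compound 3 is therefore expected to sit close to compound 2, a step of no change at the digits printed from compound 2 to compound 3 (within the scatter) in this assay. The estimate for compound 3 is 100 mg/kg, from 50 mg/kg to 200 mg/kg.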

Compound 3, minimum effective dose: 100 mg/kg
For compound 3 middle estimate and measured number coincide at the digits printed; the range from low to high includes it.
By their numbers in this assay, from the lowest: compounds 1, 2 and 3 (each within the scatter of the next).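

In this assay the aromatic ring on this amide-type nitrogen can give way to an open chain: butyl in place of 4-chlorophenyl gives no change at the digits printed from compound 2 to compound 3 (within the scatter), and butyl in place of 4-nitrophenyl gives no change at the digits printed from compound 1 to compound 3 (within the scatter). Across these three compounds, then, a six-membered aromatic ring at this place is not needed to keep the reading where it stands. Nothing measured here accounts for this flat result. On these data alone, whether a longer chain such as hexyl, or a chain carrying an amine, would read the same remains open.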